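Triazolylmethyl in place of carboxy on a double-bonded ring carbon

The source may report more compounds than this note shows. Statements on the series, on what has been measured and on what is new or still open speak of the compounds shown alone.

Working notes on three measured compounds and one to come, all tested in a functional assay on A549 cells (Homo sapiens) for antiproliferative activity, read by MTT assay, with a stated time of 48 h; on this read-out lower numbers stand for stronger inhibition and higher numbers for weaker inhibition. Compound 1 `CC(=O)OC/C1=C/C[C@](C)(CCC=C(C)C)/C=C/[C@@H](OC(=O)C=C(C)C)[C@](C)(OC(C)=O)/C=C/C1=O` gives 15100 nM in this assay. Compound 2 `C=C1/C=C/C(=O)/C(CO)=C\C[C@](C)(CCC=C(C)C)/C=C/[C@H]1OC(=O)C=C(C)C` gives 3090 nM. Compound 3 `CC(C)=CCC[C@]1(C)/C=C/[C@@H](OC(=O)C=C(C)C)[C@](C)(O)/C=C/C(=O)/C(C(=O)O)=C\C1` gives only a limit, > 10000 nM; here the assay reports no number, and the limit of > 10000 nM in this assay, at which 1 of the 3 values shown sits, is where compound 3 stands. Compound 4 `CC(C)=CCC[C@]1(C)/C=C/[C@@H](OC(=O)C=C(C)C)[C@](C)(O)/C=C/C(=O)/C(Cn2cc(CO)nn2)=C\C1` follows from compound 3 by a single change: (4-(hydroxymethyl)-1H-1,2,3-triazol-1-yl)methyl in place of carboxy on a double-bonded ring carbon. No step between two measured compounds is at hand, so the size of this step has nothing measured to lean on; the only anchor is that compound 3 sits at a limit and compound 1 sits in the weak part of the shown values. A step from compound 3 to compound 4 is expected to be small, toward stronger inhibition, and not clearly beyond the scatter. For compound 4 an estimate of 9000 nM in this assay is expected, within 2500 nM to 30000 nM, which means a step of an at least 1.1-fold lower number from compound 3 to compound 4 (0.04 log units; that floor lies within the scatter).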

Compound 4, half-maximal inhibitory concentration: 3470 nM
Beside the measured number, compound 4's estimate is 2.6-fold (0.41 log units) above it; the measured number falls inside the stated range.
By their numbers in this assay, from the lowest: compounds 2 and 4 (each within the scatter of the next); then compound 1.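

In this assay, (4-(hydroxymethyl)-1H-1,2,3-triazol-1-yl)methyl in place of carboxy on the double-bonded ring carbon gives an at least 2.8-fold lower number from compound 3 to compound 4 (0.45 log units; beyond the scatter), so this position accepts a larger group carrying a five-membered aromatic ring with 3 hetero atoms, with no loss of inhibition. This is the only step shown at this ring carbon, and in it compound 4 gives 3470 nM, a number where compound 3 has none. The step is a floor and not a size, since compound 3 stands at a limit: the limit of > 10000 nM in this assay, at which 1 of the 4 values shown sits.

From the compounds shown here alone, whether the hydroxymethyl group or the triazole ring itself carries the step remains open. So does how a methyl ester, an aminomethyl group or a longer chain to the triazole would read at this ring carbon.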